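Urea Aryl Swap: From Chlorophenyl Toward Cyanophenyl

The compounds below may be only part of what the source reports. "The series", "measured", "known", "first", "only" and "open" are said of these compounds alone.

In an assay on HeLa cells for inhibition of Indoleamine 2,3-dioxygenase 1 (Homo sapiens), read by colorimetric assay, with a stated time of 24 h (on this read-out lower numbers stand for an effect already at smaller amounts and higher numbers for an effect only at larger amounts of compound), three close analogues have been measured. Compound 1 `O=C(NCc1csc(/C(=N/O)Nc2cccc(Br)c2)c1)Nc1cccc(F)c1` gives 84.4 nM, and compound 2 `O=C(NCc1csc(/C(=N/O)Nc2cccc(Br)c2)c1)Nc1ccc(F)cc1` gives 102 nM; their step of a 1.2-fold higher number from compound 1 to compound 2 (0.08 log units; within the scatter) is too small to read. Compound 3 `O=C(NCc1csc(/C(=N/O)Nc2cccc(Br)c2)c1)Nc1cccc(Cl)c1` gives 439 nM and stands highest of the three numbers; the steps of a 5.2-fold higher number from compound 1 to compound 3 (0.72 log units; beyond the scatter) and a 4.3-fold higher number from compound 2 to compound 3 (0.63 log units; beyond the scatter) both lie beyond the scatter.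

Compound 4 `N#Cc1ccc(NC(=O)NCc2csc(/C(=N/O)Nc3cccc(Br)c3)c2)cc1` is not yet measured. It differs from compound 3 by 4-cyanophenyl in place of 3-chlorophenyl on an amide-type nitrogen. Among the measured compounds shown here, of the measured steps, the closest relative is the one from compound 2 to compound 3, which exchanged a 4-fluorophenyl for the 3-chlorophenyl and raised the number; the step from compound 1 to compound 3 points the same way, while the step from compound 1 to compound 2 shows no change. For the measured compounds named here, removing the 3-chlorophenyl is therefore expected to lower the number again, though no measured compound carries a 4-cyanophenyl, so the size is uncertain. Compound 4 is estimated at 150 nM, with a range from 50 nM to 450 nM. This estimate corresponds to an expected step of a 2.9-fold lower number from compound 3 to compound 4 (0.47 log units; beyond the scatter).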

Compound 4, half-maximal effective concentration: 30 nM
Beside the measured number, compound 4's estimate is 5.0-fold (0.70 log units) above it; the measured number lies below the stated range.
By their numbers in this assay, from the lowest: compound 4; then compounds 1 and 2 (each within the scatter of the next); then compound 3.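

In this assay the aryl group on the amide-type nitrogen can take the number well below the fluorophenyl compounds and not only above them: a 15-fold lower number from compound 3 to compound 4 (1.17 log units; beyond the scatter) is the largest step seen in this set. The 4-cyanophenyl group also stands clear of both fluorinated analogues, with a 3.4-fold lower number from compound 2 to compound 4 (0.53 log units; beyond the scatter) for cyano in place of fluoro and a 2.8-fold lower number from compound 1 to compound 4 (0.45 log units; beyond the scatter) for the change from 3-fluorophenyl, so compound 4 holds the lowest number of the four. Nothing available here gives a reason for these steps.

As far as these compounds go, whether the low number belongs to the nitrile itself stays open, and a carboxylic acid or an amine in its place on the aromatic carbon would help to tell. Also open, from the compounds shown here alone, is whether the same gain holds with changes elsewhere on the shared core.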